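The compounds below may be only part of what the source reports. "The series", "measured", "known", "first", "only" and "open" are said of these compounds alone.

Compound 3 `CCCc1nc(-c2ccccc2)c(CNCCCN2CCN(c3ccccc3OC)CC2)o1` gives 41% in an assay on HEK293 cells for inhibition of Voltage-dependent T-type calcium channel subunit alpha-1G (Homo sapiens), read by fluorescence, tested at 10 uM (on this read-out lower numbers stand for less inhibition and higher numbers for more inhibition at the one concentration tested (going by the name of the read-out)), the second highest of the three numbers in hand: compound 1 `CCCc1nc(-c2ccccc2)c(CNCCCN2CCN(c3cccc(OC)c3)CC2)o1` sits at 36.4%, within the scatter of it, while compound 2 `CCCc1nc(-c2ccccc2)c(CNCCN2CCN(C(c3ccccc3)c3ccccc3)CC2)o1` lies at 71.9%, beyond the scatter. Among the compounds with values here, the one single-place step measured, a number 4.6 percentage points higher from compound 1 to compound 3 (within the scatter), is small. Compound 4 `CCCc1nc(-c2ccccc2)c(CNCCCN2CCN(c3ccc(C(F)(F)F)cc3)CC2)o1` differs from compound 3 by 4-(trifluoromethyl)phenyl in place of 2-methoxyphenyl on an amine nitrogen in a ring. Within the data shown here, no measured step exchanges a methoxyphenyl for a trifluoromethylphenyl on the ring nitrogen, so the only comparison bearing on it is that small step, which gives no ground for a move beyond the scatter in either direction. The step of no change at the digits printed from compound 3 to compound 4 (within the scatter) is therefore expected to stay within the scatter. Compound 4 is estimated at 41%, in a range from 22% to 62%.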

Compound 4, a percentage reported as inhibition, at one concentration (the size of the read-out at that concentration, not a potency): 51.6%
For compound 4 the middle estimate is 10.6 percentage points below the measured one, within the range that was stated.
By their numbers in this assay, from the lowest: compounds 1 and 3 (each within the scatter of the next); then compound 4; then compound 2.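

In this assay, this place on the ring nitrogen does respond to the aryl group: a number 10.6 percentage points higher from compound 3 to compound 4 (beyond the scatter), and a number 15.2 percentage points higher from compound 1 to compound 4 (beyond the scatter). Within the data shown here, the exchange between the two methoxyphenyl groups, a number 4.6 percentage points higher from compound 1 to compound 3 (within the scatter), gave no such separation, so 4-(trifluoromethyl)phenyl is the first group here to stand apart. Nothing in hand speaks to what lies behind these steps.

Open, on these data alone, is whether the steps follow the trifluoromethyl group itself or its place on the phenyl ring. A 4-methoxyphenyl or a 2-(trifluoromethyl)phenyl at this nitrogen would separate the two.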